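Halogen swap on the acetate-bearing fused core

A few compounds are considered here, and "the series" means these few. Any claim that something is new, unique, unknown or untested is made for them only; others in the source may bear on it.

Measured so far:
compound 1 `CCOC(=O)Cn1cnc2c(Cl)ncnc21` – 35100 nM
compound 2 `CCOC(=O)Cn1cnc2ncnc(Br)c21` – 20200 nM

In a functional assay on MCF7 cells (Homo sapiens) for antiproliferative activity, read by colorimetric assay and sulforhodamine B assay, with a stated time of 3 days (a lower number here means a stronger inhibitor, a higher number a weaker inhibitor), compound 1 gives 35100 nM. Compound 2, which carries its bromo and its ethyl acetate arm on other positions of the fused core, gives 20200 nM in this assay. Among the measured compounds shown here, compound 1 stands beside compound 2: the gap between the two numbers lies within the scatter of repeated runs, so neither can be called the stronger or the weaker inhibitor, and no step between measured compounds is available.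

Compound 3 `CCOC(=O)Cn1cnc2c(Br)ncnc21` is not yet measured. It differs from compound 1 by bromo in place of chloro on an aromatic carbon, with the ethyl acetate arm and the rest of the core unchanged. For the measured compounds named here, both measured numbers sit high, and no pair in this assay shows a change beyond the scatter, so the step from compound 1 to compound 3 is expected to be small: an estimated 1.3-fold lower number from compound 1 to compound 3 (0.10 log units; within the scatter) in this assay, in no clear direction. For compound 3 the expected value in this assay is therefore 28000 nM, with a range from 12000 nM to 65000 nM.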

Compound 3, half-maximal inhibitory concentration: 14100 nM
Compound 3: the middle estimate sits 2.0-fold (0.30 log units) above what was measured; the measured number falls inside the stated range.
By their numbers in this assay, from the lowest: compounds 3, 2 and 1 (each within the scatter of the next, the first and the last beyond it).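

In this assay, among the compounds shown here, the halogen on this aromatic carbon, next to the ring nitrogen, does register: bromo in place of chloro gives a 2.5-fold lower number from compound 1 to compound 3 (0.40 log units; beyond the scatter) and is the first step to lie beyond the scatter. For the compounds shown here, with the ethyl acetate arm and the rest of the core unchanged, this modest step can be assigned to this one position and this one exchange, although compound 3 at 14100 nM in this assay still sits in the same high range as the earlier compounds. No measurement on hand accounts for the step, so it stands as an observation only.

From the compounds shown here alone, whether the trend from chloro to bromo continues to iodo, or whether an amine or a methoxy group on this carbon would be tolerated at all, remains open. Also open, going by these compounds, is whether the gain survives when the ethyl acetate arm gives way to a carboxylic acid or a longer chain, and whether the same exchange gives a step of like size in the arrangement of compound 2.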